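A few compounds are considered here, and "the series" means these few. Any claim that something is new, unique, unknown or untested is made for them only; others in the source may bear on it.

The three measured compounds share one core, carried in compound 1 `O=C(Nc1cc(-c2ccccc2)nn1-c1ccccc1)c1ccc([N+](=O)[O-])cc1`, compound 2 `O=C(Nc1cc(-c2ccccc2)nn1-c1ccccc1)c1ccncc1` and compound 3 `O=C(Nc1cc(-c2ccccc2)nn1-c1ccccc1)C1=CCCCC1`, and differ only in the group on the carbonyl carbon. In a functional assay on cells for positive allosteric modulation of metabotropic glutamate receptor 5 (Rattus norvegicus), read by calcium flux (on this read-out higher numbers stand for an effect only at larger amounts of compound and lower numbers for an effect already at smaller amounts), compound 1 gives 10.7 nM. In the same assay compound 2 gives 2500 nM, and compound 3 gives 3300 nM. Compound 3 thus stands at the highest number of the three: a 310-fold higher number from compound 1 to compound 3 (2.49 log units; beyond the scatter), whereas a 1.3-fold higher number from compound 2 to compound 3 (0.12 log units; within the scatter).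

Compound 4 `O=C(Nc1cc(-c2ccccc2)nn1-c1ccccc1)C1CCCC1` takes the step (cyclopentyl in place of cyclohex-1-en-1-yl on a carbonyl carbon). Going by the values given here, no measured step exchanges one non-aromatic ring for another on this carbonyl carbon. Among the compounds with values here, the steps that bear on it are a 230-fold higher number from compound 1 to compound 2 (2.37 log units; beyond the scatter), a 310-fold higher number from compound 1 to compound 3 (2.49 log units; beyond the scatter) and a 1.3-fold higher number from compound 2 to compound 3 (0.12 log units; within the scatter); together they show that leaving 4-nitrophenyl costs a great deal, while the exchange of pyridin-4-yl for cyclohex-1-en-1-yl changes little. Since compound 3 already sits at 3300 nM and the entering group is again a non-aromatic ring of carbon only, no move beyond the scatter is expected. In this assay the expected step is a 1.4-fold higher number from compound 3 to compound 4 (0.13 log units; within the scatter). Compound 4 is therefore estimated at 4500 nM, with a range from 1500 nM to 14000 nM.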

Compound 4, half-maximal effective concentration: 3410 nM
Beside the measured number, compound 4's estimate is 1.3-fold (0.12 log units) above it, and the stated range covers the measured number.
By their numbers in this assay, from the lowest: compound 1; then compounds 2, 3 and 4 (each within the scatter of the next).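

In this assay, a 1.0-fold higher number from compound 3 to compound 4 (0.01 log units; within the scatter), so replacing cyclohex-1-en-1-yl with cyclopentyl, which removes the double bond outside aromatic rings and turns the six-membered non-aromatic ring of carbon only into a five-membered one, gives no difference beyond the scatter. The new compound also matches the aromatic pyridin-4-yl compound, since a 1.4-fold higher number from compound 2 to compound 4 (0.13 log units; within the scatter) and thus stays within the scatter, while a 320-fold higher number from compound 1 to compound 4 (2.50 log units; beyond the scatter) and lies far beyond it, leaving compounds 2, 3 and 4 together and compound 1 alone apart from them. Nothing available here explains why 4-nitrophenyl stands apart from the other three groups on this carbonyl carbon.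

The compounds shown leave open whether the low number of compound 1 belongs to the nitro group or to the whole 4-nitrophenyl group, as neither an unsubstituted phenyl nor a 4-aminophenyl or 4-cyanophenyl group appears on this carbonyl carbon. They also leave open how an open chain such as butyl would compare here, and how the two phenyl groups of the shared core contribute, as those stay the same throughout.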